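The source may report more compounds than this note shows. Statements on the series, on what has been measured and on what is new or still open speak of the compounds shown alone.

Measured in a functional assay on KB403 cells (Homo sapiens) for cytotoxicity, read by MTT assay, with stated times of 6 h and 48 h; a higher number here means a weaker inhibitor, a lower number a stronger inhibitor:
- Compound 1 `Cn1c(/C=C/C(=O)c2cc(O)ccc2O)cc(Br)c1Br`: >= 100000 nM, a limit of the assay, not a number
- Compound 2 `Cn1c(-c2cc(-c3ccccc3)no2)cc(Br)c1Br`: >= 100000 nM, also a limit of the assay
- Compound 3 `Cn1c(-c2cc(-c3ccccc3O)no2)cc(Br)c1Br`: 2450 nM

Among the compounds with values here, compound 3 gives the only true number in this set. The remaining values share one ceiling, (the limit of >= 100000 nM in this assay, at which 2 of the 3 values shown sit). Compound 4 `Oc1ccccc1-c1cc(-c2cc(Br)c(Br)[nH]2)on1` differs from compound 3 in a single place, with hydrogen in place of methyl on an aromatic nitrogen.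

Within the data shown here, only one measured step exists, an at least 40-fold lower number from compound 2 to compound 3 (1.61 log units; beyond the scatter). It was large, but it concerns hydroxy in place of hydrogen on an aromatic carbon, and compound 4 keeps that hydroxy. Among the measured compounds shown here, no measured step touches the methyl, so no change beyond the scatter is expected in this assay, and no direction can be favoured. The expected step is a 1.0-fold higher number from compound 3 to compound 4 (0.01 log units; within the scatter). For compound 4 the estimated value is 2500 nM, with an expected range from 700 nM to 12000 nM.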

Compound 4, half-maximal inhibitory concentration: 16400 nM
Compound 4: the middle estimate sits 6.6-fold (0.82 log units) below what was measured; measured number above the stated range.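

In this assay, within the data shown here, hydrogen in place of methyl on the aromatic nitrogen brings a 6.7-fold higher number from compound 3 to compound 4 (0.83 log units; beyond the scatter) and so the number responds at this position, which no earlier step had touched. The methyl therefore counts for something here, although compound 4 keeps the hydroxy and still gives a true number instead of a limit. Nothing shown explains the size or direction of this step. As far as these compounds go, whether an ethyl group or a longer chain on that nitrogen would lower the number further stays open, as does whether the methyl matters as much without the hydroxy.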